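Lengthening the chain on a cyclic urea

The source may hold more compounds than are shown below. What is called first, only, known or untested is meant among the compounds shown, and "the series" means these compounds.

Measured in a functional assay on the whole organism for inhibition, with Rattus norvegicus as the target; on this read-out lower numbers stand for an effect already at smaller amounts and higher numbers for an effect only at larger amounts of compound:
Compound 1 `O=C1N(CCN2CCC(c3cn(-c4ccc(F)cc4)c4ccc(Cl)cc34)CC2)CCN1c1ccccc1`: > 0.15 umol/kg, a limit and not a number
Compound 2 `CN1CCN(CCN2CCC(c3cn(-c4ccc(F)cc4)c4ccc(Cl)cc34)CC2)C1=O`: 0.021 umol/kg
Compound 3 `O=C1NCCN1CCN1CCC(c2cn(-c3ccc(F)cc3)c3ccc(Br)cc23)CC1`: 0.032 umol/kg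

Compound 2 gives 0.021 umol/kg and compound 3 gives 0.032 umol/kg, two values within the usual scatter of each other. Compound 1 has only a limit.

Compound 4 `O=C1NCCN1CCCCCN1CCC(c2cn(-c3ccc(F)cc3)c3ccc(Cl)cc23)CC1` departs from compound 2 as follows: 3-(2-oxoimidazolidin-1-yl)propyl in place of 3-methyl-2-oxoimidazolidin-1-yl on a saturated chain carbon, two bonds along the chain from an amine nitrogen in a ring. Put another way, 2-(3-methyl-2-oxoimidazolidin-1-yl)ethyl becomes 5-(2-oxoimidazolidin-1-yl)pentyl. Among the measured compounds shown here, no measured compound carries that pentyl chain, so no measured step tests it directly.

The nearest evidence is an at least 7.1-fold lower number from compound 1 to compound 2 (0.85 log units; beyond the scatter), with methyl in place of phenyl on an amide-type nitrogen in a ring. That step shows that a change at this end of the molecule can move the number beyond the scatter. Compound 3 also keeps the amide hydrogen and gives 0.032 umol/kg, so that hydrogen alone is not expected to cost much.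

The expected change is a moderate rise in the number in this assay, a 4.8-fold higher number from compound 2 to compound 4 (0.68 log units; beyond the scatter). For compound 4 the estimated value is 0.1 umol/kg, with an expected range from 0.025 umol/kg to 0.4 umol/kg.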

Compound 4, dose for half-maximal effect: 1.5 umol/kg
Compound 4: middle estimate off by 15-fold (1.18 log units), on the low side, and the stated range ends below it.
By their numbers in this assay, from the lowest: compounds 2 and 3 (each within the scatter of the next); then compound 4.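

The step from 2-(3-methyl-2-oxoimidazolidin-1-yl)ethyl to 5-(2-oxoimidazolidin-1-yl)pentyl in this assay is a 71-fold higher number from compound 2 to compound 4 (1.85 log units; beyond the scatter). This shows that the link between the amine nitrogen in the ring and the cyclic urea is not a free place for change, whereas the earlier step tested only the group on the far nitrogen of the urea. The step from compound 1 to compound 4 cannot be read, because compound 1 carries only a limit and not a number: the limit of > 0.15 umol/kg in this assay, at which 1 of the 4 values shown sits.

As far as these compounds go, the step lengthens the chain and removes the methyl together, so how much of it belongs to each change stays open. A propyl or butyl chain to the same urea, or the pentyl chain with the methyl kept, would separate the two.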